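A few compounds are considered here, and "the series" means these few. Any claim that something is new, unique, unknown or untested is made for them only; others in the source may bear on it.

Of the compounds shown here, three sharing one core have been tested in a functional assay on the whole organism (strain albino) for inhibition, with Rattus norvegicus as the target, read by paw edema, with stated times of 1 h and 3 h, at a dose of 12 mmol/kg by the intraperitoneal route; on this read-out lower numbers stand for a weaker effect and higher numbers for a stronger effect at the one dose given. Compound 1 `N#Cc1c2n(c(=O)n(-c3ccccc3)c1=N)CCCCC2N1CCCC1` gives 65.3% in this assay. Compound 2 `CCOC(=O)C(=O)NC1=C(C#N)C2C(N3CCCC3)CCCCN2C(=O)N1c1ccccc1` gives 56.2%, and compound 3 `N#CC1=C(/N=C/c2ccc([N+](=O)[O-])cc2)N(c2ccccc2)C(=O)N2CCCCC(N3CCCC3)C12` gives 60.4%. Compound 3 thus holds the second highest of the three numbers, yet its gap to compound 2 and its gap to compound 1 both lie within the usual scatter, so no order among the three can be read from these figures. Compound 4 `N#CC1=C(N)N(c2ccccc2)C(=O)N2CCCCC(N3CCCC3)C12` differs from compound 3 in one place: one nitrogen atom in place of a group of 11 heavy atoms (7 carbon, 2 nitrogen, 2 oxygen; one six-membered aromatic ring of carbon only), on a double-bonded ring carbon. Within the data shown here, the only measured step that bears on this change is the one on the same double-bonded ring carbon, a number 4.2 percentage points higher from compound 2 to compound 3 (within the scatter), where one sizeable group replaced another without moving the read-out beyond the scatter. On that evidence, a step of a number 0.4 percentage points lower from compound 3 to compound 4 (within the scatter) is expected here, with no shift beyond the scatter in either direction. Compound 4 is therefore estimated to give 60% in this assay, within a range from 45% to 75%.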

Compound 4, a percentage reported as inhibition, in the whole organism at one dose (the size of the read-out at that dose, not a potency): 61.2%
Estimate against measurement, compound 4: 1.2 percentage points below; the measured number falls inside the stated range.
By their numbers in this assay, from the lowest: compounds 2, 3, 4 and 1 (each within the scatter of the next).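

In this assay, replacing the large group that carries the aromatic ring with a plain amino group gives a number 0.8 percentage points higher from compound 3 to compound 4 (within the scatter) on this double-bonded ring carbon, and removing the (ethoxycarbonyl)carbonyl from the amine nitrogen gives a number 5 percentage points higher from compound 2 to compound 4 (within the scatter) in the same place. With these steps, the bare amino group and both larger groups all lie within the scatter of one another, so at this one dose neither larger group is shown to be needed for the effect. Nothing measured here offers a reason for this flat picture.

From the compounds shown here alone, whether a methyl or acetyl group on this amino nitrogen would also stay within the scatter remains open, as does the outcome with a carboxylic acid in this place. With a single dose, these figures also leave open whether potency differs among these compounds.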